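The source may hold more compounds than are shown below. What is called first, only, known or untested is meant among the compounds shown, and "the series" means these compounds.

Measured compounds:
- Compound 1, `O=C(O)c1csc([C@H]2CC[C@@H]3[C@@H](CCCCCOc4ccccc4)[C@H](O)C[C@@H]3O2)n1`: 28 nM
- Compound 2, `Cc1cccc(OC[C@@H]2[C@H]3CC[C@H](c4nc(C(=O)O)cs4)O[C@H]3C[C@H]2O)c1`: 3.6 nM

Both were run in a functional assay on CHO cells for agonist activity at prostaglandin E2 receptor EP2 subtype (Homo sapiens), read by HTRF and cAMP accumulation, with a stated time of 30 min; on this read-out lower numbers stand for an effect already at smaller amounts and higher numbers for an effect only at larger amounts of compound. Of the two numbers, compound 2 has the lower one; compound 1 sits at a markedly higher concentration, and the gap between them is beyond the usual scatter. Within the data shown here, no pair that differs in a single place has been measured, so no single step is available as a yardstick for the change considered here.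

Compound 3, `O=C(O)c1csc([C@H]2CC[C@@H]3[C@@H](CCOc4ccccc4)[C@H](O)C[C@@H]3O2)n1`, has not yet been run in this assay. It carries the same atoms as compound 2, joined differently: phenoxymethyl in place of 3-methylphenoxy on a saturated chain carbon bound to a saturated ring carbon. Cut one bond further out, the change reads (3-methylphenoxy)methyl to 2-phenoxyethyl. Compound 3 thus also resembles compound 1, save that its phenoxy-bearing chain is shorter, with the same free phenoxy group. An effect only at a somewhat larger amount than for compound 2 is expected, and the step of a 4.2-fold higher number from compound 2 to compound 3 (0.62 log units; beyond the scatter) is estimated to lie beyond the scatter but short of the gap to compound 1. Compound 3 is therefore expected to give about 15 nM, with a range from 3 nM to 70 nM.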

Compound 3, half-maximal effective concentration: 1.4 nM
Compound 3: middle estimate off by 11-fold (1.03 log units), on the high side; measured number outside the range, below it.
By their numbers in this assay, from the lowest: compound 3; then compound 2; then compound 1.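

In this assay the same atoms rearranged from (3-methylphenoxy)methyl to 2-phenoxyethyl give a 2.6-fold lower number from compound 2 to compound 3 (0.41 log units; beyond the scatter) and so the way these atoms are joined at this place, not their count alone, changes the number. Compared with the longer phenoxy-bearing chain of compound 1, the change of phenoxy in place of 3-phenoxypropyl gives a 20-fold lower number from compound 1 to compound 3 (1.30 log units; beyond the scatter) and is the larger of the two steps, so of the two phenoxy chains shown, the shorter one in compound 3 has the lower number in this assay. No supporting data on why either step occurs are available here.

The change from compound 2 to compound 3 alters the chain and removes the methyl from the aromatic ring in one step, so the part played by each remains unresolved; a 2-(3-methylphenoxy)ethyl group or a plain phenoxymethyl group on the same carbon would separate the two. From the compounds shown here alone, whether the number keeps falling with chain length or turns at some intermediate length also remains open, and a 4-phenoxybutyl chain would test the range between compound 3 and compound 1.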